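Working notes: replacing the 4-methoxyphenyl of compound 3

This account rests on a few compounds, and the source may have more. Where it says the series, first, only, none or still open, it means among the compounds named here.

Compound 1 `CCOC(=O)c1c(-c2ccccc2C)[nH]c2cc(OC)ccc2c1=O`: > 100000 nM (a limit)
Compound 2 `CCOC(=O)c1c(-c2ccc(Cl)c(Cl)c2)[nH]c2cc(OC)ccc2c1=O`: 17000 nM
Compound 3 `CCOC(=O)c1c(-c2ccc(OC)cc2)[nH]c2cc(OC)ccc2c1=O`: 8000 nM

In a physicochemical assay for solubility, in phosphate buffer, at pH 7.4 (a lower number here means a less soluble compound, a higher number a more soluble compound), compound 3 gives the lowest of the two exact numbers, and compound 2 is its nearest neighbour. The entry for compound 1 is a limit only. Compound 4 `CCOC(=O)c1c(-c2cccc(Cl)c2)[nH]c2cc(OC)ccc2c1=O` carries 3-chlorophenyl in place of 4-methoxyphenyl on an aromatic carbon of the shared core. The closest measured change is the modest 2.1-fold lower number from compound 2 to compound 3 (0.33 log units; beyond the scatter), which ends on 4-methoxyphenyl. The larger at least 5.8-fold lower number from compound 1 to compound 2 (0.76 log units; beyond the scatter) and an at least 12-fold lower number from compound 1 to compound 3 (1.09 log units; beyond the scatter) start from a limit and bear less. A modest step to a higher number is therefore expected. Compound 4 is expected at 18000 nM, with an estimated range of 7000 nM to 50000 nM. The estimated step is a 2.3-fold higher number from compound 3 to compound 4 (0.35 log units; beyond the scatter).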

Compound 4, solubility: 58000 nM
Estimate against measurement, compound 4: 3.2-fold (0.51 log units) below; measured number above the stated range.
By their numbers in this assay, from the lowest: compound 3; then compound 2; then compound 4. At a limit, above all of these: compound 1.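

In this assay 3-chlorophenyl in place of 4-methoxyphenyl on an aromatic carbon gives a 7.3-fold higher number from compound 3 to compound 4 (0.86 log units; beyond the scatter), a wider spread than the exact values of compound 2 and compound 3 had shown. Removing one chloro from the 3,4-dichlorophenyl alone gives a 3.4-fold higher number from compound 2 to compound 4 (0.53 log units; beyond the scatter), so a single substituent on this phenyl ring moves the number beyond the scatter. The remaining step is an at least 1.7-fold lower number from compound 1 to compound 4 (0.23 log units; that floor lies within the scatter). Compound 1 stands at a limit: the limit of > 100000 nM in this assay, at which 1 of the 4 values shown sits.

Going by these compounds, whether an amine or a carboxylic acid on this phenyl ring would raise the number further stays open. On these data alone, the effect of an amide in place of the ethoxycarbonyl group also stays open.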